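Phenylsulfanyl for Phenoxy: Stability in Human Liver Microsomes

A few compounds are considered here, and "the series" means these few. Any claim that something is new, unique, unknown or untested is made for them only; others in the source may bear on it.

Compound 1 `COc1cc(OCc2cccc(C#N)c2)c2cc(-c3cn4nc(OC)sc4n3)oc2c1`: 100%
Compound 2 `COc1cc(OCc2cccc(Oc3ccccc3)c2)c2cc(-c3cn4nc(OC)sc4n3)oc2c1`: 86%

In an ADME assay on microsomes from liver (Homo sapiens) for metabolic stability, with a stated time of 10 min (on this read-out higher numbers stand for a more stable compound and lower numbers for a less stable compound), compound 2 gives 86%, the lower of the two numbers; compound 1 gives 100%. Among the measured compounds shown here, the one measured step, a number 14 percentage points lower from compound 1 to compound 2 (beyond the scatter), concerns a different change. Compound 3 `COc1cc(OCc2cccc(Sc3ccccc3)c2)c2cc(-c3cn4nc(OC)sc4n3)oc2c1` differs from compound 2 by phenylsulfanyl in place of phenoxy on an aromatic carbon. For the measured compounds named here, no measured step exchanges phenoxy for phenylsulfanyl, so the expectation rests on compound 2 alone, and a step no larger than the scatter is expected, a number 6 percentage points lower from compound 2 to compound 3 (within the scatter). Compound 3 is therefore estimated at 80%, with a range from 60% to 95%.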

Compound 3, percent of the compound remaining: 80%
The estimate for compound 3 equals the measured number at the digits printed; the measured number falls inside the stated range.
By their numbers in this assay, from the lowest: compounds 3 and 2 (each within the scatter of the next); then compound 1.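

In this assay, replacing phenoxy with phenylsulfanyl on this aromatic carbon gives a number 6 percentage points lower from compound 2 to compound 3 (within the scatter), so exchanging oxygen for sulfur in this group leaves the read-out within the usual scatter. Phenylsulfanyl in place of cyano gives a number 20 percentage points lower from compound 1 to compound 3 (beyond the scatter), which places compound 3 with compound 2 and apart from compound 1. Nothing available here explains either step. On these data alone, whether a phenylamino group or a carboxylic acid on this aromatic carbon would stand with compound 2 and compound 3 or with compound 1 remains open.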